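Phenyl removal from compound 2: working notes

The source may report more compounds than this note shows. Statements on the series, on what has been measured and on what is new or still open speak of the compounds shown alone.

Measured in a functional assay on MOLT-4 cells (Homo sapiens) for cytotoxicity, read by CCK-8 assay, with a stated time of 24 h; on this read-out higher numbers stand for weaker inhibition and lower numbers for stronger inhibition:
- compound 1 `C=CC(=O)N1C(=O)CC(c2ccccc2C(F)(F)F)Sc2ccccc21`: 84400 nM
- compound 2 `C=CC(=O)N1C(=O)CC(c2ccc(-c3ccccc3)cc2)Sc2ccccc21`: 97500 nM

Compound 2 stands within the usual scatter of compound 1, so these two values set no order. Compound 3 `C=CC(=O)N1C(=O)CC(c2ccccc2)Sc2ccccc21` is not yet measured. It carries hydrogen in place of phenyl on an aromatic carbon, para to a large group (hydrogen in place of phenyl on an aromatic carbon). Within the data shown here, no measured step in this assay isolates this change. With compound 2 at 97500 nM, no step beyond the scatter is expected. The expected change is a 1.4-fold lower number from compound 2 to compound 3 (0.14 log units; within the scatter). For compound 3 the estimated value is 70000 nM, with an expected range of 25000 nM to 150000 nM.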

Compound 3, half-maximal inhibitory concentration: 85900 nM
Compound 3: middle estimate off by 1.2-fold (0.09 log units), on the low side; the range from low to high includes it.
By their numbers in this assay, from the lowest: compounds 1, 3 and 2 (each within the scatter of the next).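

In this assay, hydrogen in place of phenyl gives a 1.1-fold lower number from compound 2 to compound 3 (0.06 log units; within the scatter) and hydrogen in place of trifluoromethyl gives a 1.0-fold higher number from compound 1 to compound 3 (0.01 log units; within the scatter). With hydrogen now measured as the reference point, neither phenyl nor trifluoromethyl is told apart from it on this read-out. No measurement available here accounts for this lack of separation. Still open, from the compounds shown here alone, is whether an amine or a carboxylic acid on this aromatic carbon would give a step beyond the scatter. Also open, going by these compounds, is whether changes to the shared core would do so.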